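The source may report more compounds than this note shows. Statements on the series, on what has been measured and on what is new or still open speak of the compounds shown alone.

Measured so far:
Compound 1, `CCOC(=O)c1ccc(-c2nn(C(C)C)c3ccccc23)cc1`, in a functional assay on cells (Platelet, Homo sapiens) for inhibition (a higher number here means a weaker inhibitor, a lower number a stronger inhibitor), compound 1 gives 650 nM.
Compound 2, `CNC(=O)c1ccc(-c2nn(Cc3ccccc3)c3ccccc23)cc1`, in this assay compound 2 gives > 10000 nM.

The value shown for compound 2 is a limit of this assay, not a number: it sits at the limit of > 10000 nM in this assay, at which 1 of the 2 values shown sits. So compound 2 stands at the weak end of what the two measured compounds show, while compound 1 is the only one with a full number.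

Compound 3, `CCOC(=O)/C=C/c1ccc(-c2nn(Cc3ccccc3)c3ccccc23)cc1`, has not yet been measured in this assay. It differs from compound 2 in one place: 2-(ethoxycarbonyl)ethenyl in place of methylcarbamoyl on an aromatic carbon, para to a large group. Within the data shown here, no step between measured compounds tells how large such a change is. Compound 1 carries an ethyl ester and gives 650 nM, and compound 3 also carries an ethyl ester, though on a longer chain and beside a benzyl group on the shared core as in compound 2. The expected direction is therefore toward stronger inhibition, a step from a limit to a number, as an at least 3.3-fold lower number from compound 2 to compound 3 (0.52 log units; beyond the scatter) describes. For compound 3 the estimate is 3000 nM, within 800 nM to 15000 nM.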

Compound 3, half-maximal inhibitory concentration: > 10000 nM
Compound 3: only a limit was reported; the forecaster's own chance of this, stated with the estimate: 30%; middle value at least 3.3-fold (0.52 log units) away from the limit.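

No step can be read between compound 2 and compound 3, because both values are limits and not numbers in this assay: the limit of > 10000 nM in this assay, at which 2 of the 3 values shown sit.

The compounds shown leave open how strongly either compound inhibits, and whether 2-(ethoxycarbonyl)ethenyl in place of methylcarbamoyl changes the inhibition at all.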